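The source may report more compounds than this note shows. Statements on the series, on what has been measured and on what is new or still open speak of the compounds shown alone.

- Compound 1 `C=CCC/C=C\C=C/CCCCCCCC[C@@H]1CC[C@@H]([C@@H]2CC[C@@H](CC(=O)OC)OO2)O1`: 0.1 ug/mL
- Compound 2 `C=CCC/C=C\C=C/CCCCCCCC[C@H]1CC[C@H]([C@@H]2CC[C@@H](CC(=O)OC)OO2)O1`: 0.1 ug/mL

In a functional assay on DU-145 cells (Homo sapiens) for cytotoxicity (on this read-out higher numbers stand for weaker inhibition and lower numbers for stronger inhibition), compound 2 gives 0.1 ug/mL, level with compound 1 at 0.1 ug/mL. The next structure, compound 3 `C=CCCC/C=C/C=C\CCCCCCCC[C@H]1CC[C@H]([C@@H]2CC[C@@H](CC(=O)OC)OO2)O1`, changes the chain of compound 2: a group of 7 heavy atoms (7 carbon; no ring) in place of a group of 6 heavy atoms (6 carbon; no ring), on a double-bonded chain carbon bound to a double-bonded chain carbon. For the measured compounds named here, the only measured step, no change at the digits printed from compound 1 to compound 2 (within the scatter), bears on this only indirectly, since it reflects (the fact that compounds 1 and 2 differ only in the configuration as drawn). Going by the values given here, no measured step alters the chain, so the expectation is weakly grounded, and no shift beyond the scatter is expected in this assay. The expected change is no change at the digits printed from compound 2 to compound 3 (within the scatter). For compound 3, the estimated value is 0.1 ug/mL, with an expected range of 0.04 ug/mL to 0.3 ug/mL.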

Compound 3, half-maximal inhibitory concentration: 0.1 ug/mL
For compound 3 middle estimate and measured number coincide at the digits printed; low and high end bracket the measured number.
By their numbers in this assay, from the lowest: compounds 1, 2 and 3 (each within the scatter of the next).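

In this assay, for the compounds shown here, placing a hepta-1,6-dien-1-yl group on a double-bonded chain carbon bound to a double-bonded chain carbon, where a group of 6 heavy atoms stood, gives no change at the digits printed from compound 2 to compound 3 (within the scatter) and so adds a first measured change to the chain itself. At this position, the chain can therefore take this particular replacement with the read-out staying level. Nothing given here explains this outcome.

As far as these compounds go, it remains open whether a much longer chain, or a chain ending in an amine or a carboxylic acid, would also stay level.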